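A few compounds are considered here, and "the series" means these few. Any claim that something is new, unique, unknown or untested is made for them only; others in the source may bear on it.

Measured so far:
compound 1 `Cc1cc(Cl)c2oc(N3CCN(C)CC3)nc2c1` — 0.26
compound 2 `COc1cc(Cl)cc2nc(N3CCN(C)CC3)oc12` — 0.62

Of the compounds shown here, two have been measured in an assay on ileum (strain Hartley) with 5-hydroxytryptamine receptor 3A (Cavia porcellus) as the target; on this read-out lower numbers stand for smaller maximal responses and higher numbers for larger maximal responses. Compound 1 gives 0.26, and compound 2 gives 0.62. On these two numbers compound 2 stands highest; its nearest neighbour is compound 1, and the gap between them is beyond the usual scatter. The two differ in more than one place, so nothing can be said about which part of the structure accounts for the gap.

Compound 3 `COc1cc(C)cc2nc(N3CCN(C)CC3)oc12` has not been measured. It differs from compound 2 in a single spot: methyl in place of chloro on an aromatic carbon. One heavy atom leaves and one heavy atom enters, and no donor, acceptor or charge is changed.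

Among the measured compounds shown here, no measured pair here isolates such a swap, so the expected size of the step in this assay can only be a cautious guess. A modest downward step is expected, near the edge of the scatter. The step expected from the change is a number 0.12 lower from compound 2 to compound 3 (beyond the scatter). Compound 3 is therefore estimated to give 0.5, with a likely range from 0.3 to 0.7.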

Compound 3, intrinsic activity: the largest response reached, as a fraction of the reference agonist's: 0.56
Estimate against measurement, compound 3: 0.060 below, within the range that was stated.
By their numbers in this assay, from the lowest: compound 1; then compounds 3 and 2 (each within the scatter of the next).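

In this assay, the step for methyl in place of chloro on this aromatic carbon, meta to the methoxy group, is a number 0.060 lower from compound 2 to compound 3 (within the scatter), so this read-out does not separate these two groups at this position. Compound 3 also forms the first single-change pair involving the methoxy group: with the methyl group held constant, methoxy in place of chloro at a different aromatic carbon gives a step of a number 0.30 higher from compound 1 to compound 3 (beyond the scatter), so in this pair, unlike the swap at the first position, the change exceeds the scatter. Nothing available explains either result.

These comparisons rest on one pair for each change, so they cannot show whether a much larger or more polar replacement, such as an amine or a carboxylic acid, would also leave the read-out unchanged at the position meta to the methoxy group. From the compounds shown here alone, it also remains open whether the higher number seen with methoxy depends on its oxygen or on its methyl part, which a hydroxyl group or a longer chain such as ethoxy at that carbon could help to separate.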